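Working notes: 4-cyanophenyl in place of 3-fluorophenyl

The source may report more compounds than this note shows. Statements on the series, on what has been measured and on what is new or still open speak of the compounds shown alone.

Measured in an ADME assay on HeLa cells (Homo sapiens) for inhibition, read by MTT assay, with a stated time of 48 h; on this read-out higher numbers stand for weaker inhibition and lower numbers for stronger inhibition:
- Compound 1 `O=C(/C=C/c1cc(C(=O)c2ccccc2F)c[nH]1)CC(=O)C(=O)O`: > 40000 nM, a limit
- Compound 2 `O=C(/C=C/c1cc(C(=O)c2cccc(F)c2)c[nH]1)CC(=O)C(=O)O`: > 40000 nM, a limit

Compound 2 stands at > 40000 nM, which is a limit and not a number. Among the compounds with values here, the series so far rests entirely on (the limit of > 40000 nM in this assay, at which 2 of the 2 values shown sit), so no measured number places compound 2 within the series.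

Compound 3 `N#Cc1ccc(C(=O)c2c[nH]c(/C=C/C(=O)CC(=O)C(=O)O)c2)cc1` carries 4-cyanophenyl in place of 3-fluorophenyl on a carbonyl carbon.

Within the data shown here, one measured step bears on this change, as it also alters the group on a carbonyl carbon: a step that the two limits leave unreadable from compound 1 to compound 2. That step has no readable size, so it offers no size or direction to carry forward. No step beyond the scatter is therefore expected in this assay, though the data cannot exclude one. This expectation rests on compound 2, whose value of > 40000 nM is a limit.

The expected change is a step that the limit leaves unreadable from compound 2 to compound 3. The estimate for compound 3 is 45000 nM, with an expected range of 15000 nM to 100000 nM.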

Compound 3, half-maximal inhibitory concentration: > 40000 nM
Compound 3: only a limit was reported; the forecaster's own chance of this, stated with the estimate: 80%; the middle value lies beyond the limit too.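

No new step can be read among compound 1, compound 2 and compound 3 in this assay, since all three values are limits and not numbers: the limit of > 40000 nM in this assay, at which 3 of the 3 values shown sit.

The compounds shown leave open whether 2-fluorophenyl, 3-fluorophenyl and 4-cyanophenyl on a carbonyl carbon differ at all on this read-out, and what half-maximal inhibitory concentration any of the three compounds has.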